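This account rests on a few compounds, and the source may have more. Where it says the series, first, only, none or still open, it means among the compounds named here.

Measured in a functional assay for inhibition, with Rattus norvegicus as the target; on this read-out lower numbers stand for stronger inhibition and higher numbers for weaker inhibition:
- compound 1 `C[C@@H](/N=c1\c(O)c(O)\c1=N/c1ccc(C#N)cc1)C(C)(C)C`: 370 nM; 24300 nM (2 entries)
- compound 2 `C[C@@H](/N=c1\c(O)c(O)\c1=N/c1ccc(C#N)c(Cl)c1)C(C)(C)C`: 4300 nM

For the measured compounds named here, the only number for compound 2 is 4300 nM, and one further entry gave no single number. That value falls between the two entries for compound 1, 370 nM; 24300 nM (2 entries).

Compound 3 `Cc1cc(/N=c2\c(O)c(O)\c2=N/[C@H](C)C(C)(C)C)ccc1C#N` differs from compound 2 as follows: methyl in place of chloro on an aromatic carbon. The exchange takes place ortho to a cyano group. Going by the values given here, no measured step bears on this exchange, so no direction is expected in this assay, and no step beyond the scatter is expected. The estimate amounts to a 1.2-fold lower number from compound 2 to compound 3 (0.09 log units; within the scatter), an expected shift inside the scatter. The range stays wide because of the several entries of compound 1 in this assay, 370 nM; 24300 nM (2 entries), which show how far apart repeat entries for compound 1 lie. Compound 3 is expected at 3500 nM, with an estimated range of 500 nM to 25000 nM.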

Compound 3, half-maximal inhibitory concentration: 630 nM
Estimate against measurement, compound 3: 5.6-fold (0.74 log units) above; the measured number falls inside the stated range.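

In this assay, the position ortho to a cyano group does not treat chloro and methyl alike: a 6.8-fold lower number from compound 2 to compound 3 (0.83 log units; beyond the scatter). For the compounds shown here, this is the only step that can be read at this position, and it separates two groups of one heavy atom each, neither with a hydrogen-bond donor or acceptor. Compound 1 carries neither group and gives no clear reference, as the values of compound 2 and compound 3 both lie inside the wide span of its repeat entries: the several entries of compound 1 in this assay, 370 nM; 24300 nM (2 entries)

Still open, on these data alone, is whether the lower number of compound 3 comes from gaining methyl or from losing chloro. Also open, as far as these compounds go, is how this position reads with a methoxy, trifluoromethyl or amine group, or with a longer chain such as ethyl.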